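Piperazine amide series: thioether acetyl replaces aryl propanoyl

This account rests on a few compounds, and the source may have more. Where it says the series, first, only, none or still open, it means among the compounds named here.

Working notes on the shared core of compound 2. Compound 2 `COc1ccc(CC(C)C(=O)N2CCN(c3ccc(C(F)(F)F)cc3[C@@H](N)CC(C)C)CC2)cc1F` in an assay on HEK293 cells for displacement of a labelled ligand from Melanocortin receptor 4 (Homo sapiens) (on this read-out lower numbers stand for stronger inhibition and higher numbers for weaker inhibition), gives 200 nM; a further entry for compound 2 carries no single number. Compound 1 `CC(C)C[C@H](N)c1cc(C(F)(F)F)ccc1N1CCN(C(=O)C(C)Cc2ccc(Cl)c(Cl)c2)CC1` in this assay gives 120 nM; 1600 nM (2 entries), and the spread of its entries the several entries of compound 1 in this assay, 120 nM; 1600 nM (2 entries) shows that repeats on this core can disagree widely. For the measured compounds named here, no pair of measured compounds differing in one place is available, so compound 1 and compound 2 show only that two different aryl-bearing amide groups both land in the same general range.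

Compound 3 `CC(C)C[C@H](N)c1cc(C(F)(F)F)ccc1N1CCN(C(=O)CSc2ccc(Cl)cc2Cl)CC1` is still to be measured in this assay. Against compound 2 the change is ((2,4-dichlorophenyl)sulfanyl)methyl in place of 1-(3-fluoro-4-methoxybenzyl)ethyl on a carbonyl carbon. Compound 1 also carries a dichlorophenyl on its amide and gives 120 nM; 1600 nM (2 entries), so a dichlorinated ring is tolerated, while the thioether spacer is new to the set. A small loss, or none beyond the scatter, is expected for compound 3, estimated at 400 nM with a range of 100 nM to 2000 nM; the expected step is a 2.0-fold higher number from compound 2 to compound 3 (0.30 log units; within the scatter).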

Compound 3, inhibition constant: 1500 nM
Compound 3: middle estimate off by 3.8-fold (0.57 log units), on the low side; measured number inside the range.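

In this assay, for the compounds shown here, exchanging the group on the carbonyl carbon gives a 7.5-fold higher number from compound 2 to compound 3 (0.88 log units; beyond the scatter), the first step in this set read between compounds that differ in one place. This position is therefore not indifferent to the group it carries: with the rest of the structure held constant, this exchange alone weakens inhibition beyond the scatter. The size of the step still needs caution, because repeats on this core can disagree widely: the several entries of compound 1 in this assay, 120 nM; 1600 nM (2 entries)

The exchange alters the spacer and the aromatic ring together, so the compounds shown do not separate the contribution of the sulfur from that of the two chlorines or of the lost fluoro and methoxy groups. Also open, on these data alone, is how this position would respond to an oxygen atom in place of the sulfur, a longer chain between the carbonyl and the ring, or an amine or carboxylic acid on that chain.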